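Fluoro on the aryl ring of a triazole series

This account rests on a few compounds, and the source may have more. Where it says the series, first, only, none or still open, it means among the compounds named here.

Two compounds define the set so far: compound 1 `CC[C@H](CCn1cncn1)c1ccc(F)cc1` and compound 2 `CCC[C@H](CCn1cncn1)c1ccccc1`. In an ADME assay on RD cells (Homo sapiens) for cytotoxicity, read by MTT assay, with a stated time of 3 days (a lower number here means that less compound is tolerated, a higher number that more compound is tolerated), compound 1 gives 110 ug/mL, and in this assay compound 2 gives 63.1 ug/mL, a pair that lies within the scatter of each other, so compound 2 stands alongside compound 1 rather than apart from it. Compound 3 `CCC[C@H](CCn1cncn1)c1ccc(F)cc1` follows from compound 2 by fluoro in place of hydrogen on an aromatic carbon. Within the data shown here, no measured pair carries this exact change, so no step beyond the scatter is expected here; the estimated step of a 1.3-fold higher number from compound 2 to compound 3 (0.10 log units; within the scatter) stays small. Compound 3 is expected to give about 80 ug/mL in this assay, with a range from 40 ug/mL to 160 ug/mL.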

Compound 3, half-maximal cytotoxic concentration: 38.4 ug/mL
Compound 3: the middle estimate sits 2.1-fold (0.32 log units) above what was measured; the measured number lies below the stated range.
By their numbers in this assay, from the lowest: compounds 3, 2 and 1 (each within the scatter of the next, the first and the last beyond it).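

Fluoro in place of hydrogen on an aromatic carbon, para to a large group, now has a measured step in this assay (a 1.6-fold lower number from compound 2 to compound 3 (0.22 log units; within the scatter)), and this step stays within the scatter. Among these compounds, with fluoro in place, methyl in place of hydrogen on a saturated chain carbon, three bonds along the chain from an aromatic carbon, gives the only step beyond the scatter (a 2.9-fold lower number from compound 1 to compound 3 (0.46 log units; beyond the scatter)), though a modest one. Open, on these data alone, is how a chloro or methoxy group at this ring position, or a longer chain, would read. No measured evidence here accounts for either step.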